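From methylsulfonyl to 2-methoxyethoxy in the series

The source may report more compounds than this note shows. Statements on the series, on what has been measured and on what is new or still open speak of the compounds shown alone.

In an in vivo ADME assay on the whole organism (Cercopithecidae) for pharmacokinetics, at a dose of 3 mg/kg by the intravenous route (on this read-out lower numbers stand for a shorter-lived compound and higher numbers for a longer-lived compound), compound 2 `CC1(C)NC(=O)N(CC(COc2ccc(-c3ccc(S(C)(=O)=O)cc3)cc2)N(O)C=O)C1=O` gives 5 h, within the scatter of compound 1 `CC1(C)NC(=O)N(CC(COc2ccc(-c3ccc(C#N)cc3)cc2)N(O)C=O)C1=O` at 8 h. Compound 3 `COCCOc1ccc(-c2ccc(OCC(CN3C(=O)NC(C)(C)C3=O)N(O)C=O)cc2)cc1` differs from compound 2 by 2-methoxyethoxy in place of methylsulfonyl on an aromatic carbon, with 2-methoxyethoxy in place of methylsulfonyl on an aromatic carbon. Among the compounds with values here, the one measured step at this place is a 1.6-fold lower number from compound 1 to compound 2 (0.20 log units; within the scatter), which stays within the scatter. Within the data shown here, no measured compound carries 2-methoxyethoxy, so no step beyond the scatter is expected in this assay, in either direction. The expected step is no change at the digits printed from compound 2 to compound 3 (within the scatter). For compound 3 the estimate is 5 h, with an expected range of 2.5 h to 10 h.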

Compound 3, half-life: 1 h
Beside the measured number, compound 3's estimate is 5.0-fold (0.70 log units) above it; the whole stated range lies above it.
By their numbers in this assay, from the lowest: compound 3; then compounds 2 and 1 (each within the scatter of the next).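

The position is not indifferent to its substituent in this assay: 2-methoxyethoxy in place of methylsulfonyl gives a 5.0-fold lower number from compound 2 to compound 3 (0.70 log units; beyond the scatter) and in place of cyano gives an 8.0-fold lower number from compound 1 to compound 3 (0.90 log units; beyond the scatter). Methylsulfonyl and cyano remain within the scatter of each other, so only 2-methoxyethoxy separates from the others. Nothing available explains this fall.

As far as these compounds go, whether it belongs to the whole 2-methoxyethoxy chain or only to its first oxygen stays open, and a plain methoxy or a longer alkyl chain would bear on that. From the compounds shown here alone, how an amine or a carboxylic acid reads at this position also stays open.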